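From Allylcarbamoyl to Bromophenylsulfonyl on an Aromatic Nitrogen

The source may hold more compounds than are shown below. What is called first, only, known or untested is meant among the compounds shown, and "the series" means these compounds.

Compound 1 `C=CCNC(=O)n1c(-c2ccc(OC)cc2)cc(=O)c2c(OC)cc(OC)cc21` was examined in a functional assay on HepG2 cells (Homo sapiens) for antiproliferative activity, with a stated time of 72 h; on this read-out lower numbers stand for an effect already at smaller amounts and higher numbers for an effect only at larger amounts of compound. In this assay compound 1 reaches only the limit > 20000 nM, so no number is known for it. Compound 2 `COC(=O)c1cc(=O)c2c(OC)cc(OC)cc2[nH]1` likewise stops at the limit > 34400 nM in this assay. Compound 3 `COC(=O)c1cc(=O)c2cc(N)ccc2[nH]1` also stops at the limit > 33700 nM in this assay. Compound 1 therefore stands among three results none of which is a number; where each sits is told by the limit of > 20000 nM in this assay, at which 1 of the 3 values shown sits, the limit of > 33700 nM in this assay, at which 1 of the 3 values shown sits, and (the limit of > 34400 nM in this assay, at which 1 of the 3 values shown sits). Going by the values given here, no two of the measured compounds differ in a single place, so no measured step is available to guide an expectation.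

Compound 4 `COc1ccc(-c2cc(=O)c3c(OC)cc(OC)cc3n2S(=O)(=O)c2cccc(Br)c2)cc1` carries the change ((3-bromophenyl)sulfonyl in place of allylcarbamoyl on an aromatic nitrogen). Among the compounds with values here, with compound 1 at a limit and no measured step to lean on, the step expected in this assay is a number no higher from compound 1 to compound 4 (the limit leaves the size open), and it is not expected to reach beyond the scatter. Compound 4 is accordingly estimated at 20000 nM, with a range from 5000 nM to 80000 nM, and a further limit rather than a number is the more likely outcome.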

Compound 4, half-maximal effective concentration: > 58600 nM
Compound 4: only a limit was reported (the forecaster's own chance of this, stated with the estimate: 65%); middle value at least 2.9-fold (0.46 log units) away from the limit.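

Compound 1 and compound 4 both give only limits, not numbers, in this assay, and the step between them cannot be read. The compounds shown leave open whether either allylcarbamoyl or (3-bromophenyl)sulfonyl on the aromatic nitrogen allows any measurable effect on these cells.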